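This account rests on a few compounds, and the source may have more. Where it says the series, first, only, none or still open, it means among the compounds named here.

Compound 2 `O=C(CN1CCN(c2ccc([N+](=O)[O-])cc2)CC1)C(O)(c1ccccc1)C1CCC1` and compound 1 `COc1ccccc1N1CCN(CC(=O)C(O)(c2ccccc2)C2CCC2)CC1` share one core and differ only in the group on the ring nitrogen. In a functional assay on ileum for antagonist activity at muscarinic acetylcholine receptor M3 (Cavia porcellus) (on this read-out lower numbers stand for stronger inhibition and higher numbers for weaker inhibition), compound 2 gives > 10000 nM, which is a limit of the assay and not a number. In this assay compound 1 gives > 10000 nM, likewise a limit. Among the measured compounds shown here, the one measured step is a step that the two limits leave unreadable from compound 1 to compound 2, with both ends at the limit of > 10000 nM in this assay, at which 2 of the 2 values shown sit, so neither its size nor its direction can be read. Compound 3 `O=C(CN1CCN(Cc2ccco2)CC1)C(O)(c1ccccc1)C1CCC1` carries (furan-2-yl)methyl in place of 4-nitrophenyl on an amine nitrogen in a ring. For the measured compounds named here, only that unreadable step bears on this change; the two measured compounds show merely that either group on that ring nitrogen leaves the value at the limit, and nothing measured points beyond the scatter in either direction. On that basis an estimated step of an at least 1.2-fold lower number from compound 2 to compound 3 (0.09 log units; that floor lies within the scatter) is expected. For compound 3 the estimated value in this assay is 8000 nM, with an expected range from 1500 nM to 40000 nM, and a limit rather than a number remains the more likely outcome.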

Compound 3, antagonist equilibrium constant: 750 nM
Compound 3: middle estimate off by 11-fold (1.03 log units), on the high side, outside the stated range (below it).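

In this assay, among the compounds shown here, exchanging 4-nitrophenyl for (furan-2-yl)methyl on the amine nitrogen in the ring gives an at least 13-fold lower number from compound 2 to compound 3 (1.12 log units; beyond the scatter) and yields the only value among the three compounds that is a number and not a limit. Exchanging 2-methoxyphenyl for the same group gives an at least 13-fold lower number from compound 1 to compound 3 (1.12 log units; beyond the scatter) and shows that the lower number does not depend on which of these two phenyl groups is replaced, so this position can move the read-out on the shared core, which the earlier pair could not show. Both steps are only floors, and the step between compound 1 and compound 2 cannot be read, so the two substituted phenyl groups cannot be ranked against each other: the limit of > 10000 nM in this assay, at which 2 of the 3 values shown sit.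

On these data alone, it remains open whether the lower number comes with the furan ring itself or with the methyl link that joins it to the ring nitrogen, a question that benzyl or (thiophen-2-yl)methyl on that nitrogen would address. As far as these compounds go, the true size of both steps also remains open, as does whether a plain phenyl group directly on that nitrogen would stay at the limit.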